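Sulfonamide aryl swap on an imidazolidinone core

This account rests on a few compounds, and the source may have more. Where it says the series, first, only, none or still open, it means among the compounds named here.

Measured so far:
compound 1 `O=C1NCCN1c1ccc(S(=O)(=O)Nc2ccc3[nH]ccc3c2)cc1` — 130 nM
compound 2 `Cc1cccc(NS(=O)(=O)c2ccc(N3CCNC3=O)cc2)c1` — 110 nM

Both compounds were tested in a functional assay on HT-29 cells (Homo sapiens) for antiproliferative activity, read by sulforhodamine B assay, with a stated time of 48 h; a lower number here means a stronger inhibitor, a higher number a weaker inhibitor. In this assay compound 1 gives 130 nM and compound 2 gives 110 nM. Of the two numbers, that of compound 2 is the lower, yet the gap to compound 1 lies within the usual scatter, so the two cannot be told apart on these data.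

Compound 3 `Cc1ccccc1NS(=O)(=O)c1ccc(N2CCNC2=O)cc1` has not yet been measured. It is built from compound 2 by 2-methylphenyl in place of 3-methylphenyl on a sulfonamide nitrogen. Going by the values given here, no measured pair shows the effect of such a change, so the expectation rests on the closeness of the two measured values alone. A modest step is expected, toward a weaker inhibitor if anything, with a 1.8-fold higher number from compound 2 to compound 3 (0.26 log units; within the scatter) as the estimated shift. Compound 3 is therefore expected to give about 200 nM, within a range from 70 nM to 600 nM.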

Compound 3, half-maximal inhibitory concentration: 200 nM
Compound 3: the middle estimate sits on the measured number at the digits printed, and the stated range covers the measured number.
By their numbers in this assay, from the lowest: compounds 2, 1 and 3 (each within the scatter of the next).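

With 2-methylphenyl in place of 3-methylphenyl on a sulfonamide nitrogen, this assay gives a 1.8-fold higher number from compound 2 to compound 3 (0.26 log units; within the scatter). Going by these compounds alone, this is the first measured pair in which only this one place differs: the two groups have the same atoms, joined differently, and the rest of the structure is held fixed. On this evidence, this assay does not tell these two methylphenyl groups apart, and nothing given here offers a cause for the size of the step.

As far as these compounds go, it remains open how an unsubstituted phenyl, a methoxyphenyl or a phenyl bearing a carboxylic acid would read on this sulfonamide nitrogen. From the compounds shown here alone, it also remains open whether an amine or a longer chain on the shared core would produce a step beyond the scatter.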